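Cyclopropyl for tert-butyl on the aryl group

This account rests on a few compounds, and the source may have more. Where it says the series, first, only, none or still open, it means among the compounds named here.

In an assay on membranes from Jurkat cells for displacement of a labelled ligand from Sigma intracellular receptor 2 (Homo sapiens), read by scintillation counting, with a stated time of 1 h (on this read-out higher numbers stand for weaker inhibition and lower numbers for stronger inhibition), compound 1 `Cn1nc(CN2CCCC2)nc1-c1cccc(-c2ccccc2)c1` gives 1000 nM. Compound 2 `Cn1nc(CN2CCCC2)nc1-c1cccc(C(C)(C)C)c1` gives 1000 nM in this assay. Within the data shown here, the single measured step, no change at the digits printed from compound 1 to compound 2 (within the scatter), tert-butyl in place of phenyl on an aromatic carbon, is flat within the scatter. Among the measured compounds shown here, compound 2 therefore stands level with compound 1 on the numbers to hand, and no measured compound is separated from it beyond the scatter.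

Compound 3 `Cn1nc(CN2CCCC2)nc1-c1cccc(C2(C(F)(F)F)CC2)c1` differs from compound 2 by 1-(trifluoromethyl)cyclopropyl in place of tert-butyl on an aromatic carbon. For the measured compounds named here, no measured step makes this exchange. Going by the values given here, the only step at the same place, no change at the digits printed from compound 1 to compound 2 (within the scatter), showed no movement between two quite different groups, so the expectation in this assay for compound 3 is no step beyond the scatter, with a wider range because no change at the digits printed from compound 1 to compound 2 (within the scatter) is the sole precedent and the new group has no direct comparator. The step from compound 2 to compound 3 is thus expected to be no change at the digits printed from compound 2 to compound 3 (within the scatter). Compound 3 is estimated at 1000 nM, within 300 nM to 3500 nM.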

Compound 3, inhibition constant: > 1000 nM
Compound 3: only a limit was reported (the forecaster's own chance of this, stated with the estimate: 10%); the middle value sits exactly at the limit.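

The reading for compound 3 in this assay is a limit and not a number. The two steps to it are a number no lower from compound 1 to compound 3 (the limit leaves the size open) and a number no lower from compound 2 to compound 3 (the limit leaves the size open) and neither can be read for size. The change still adds one piece of information: a third group on this aromatic carbon, 1-(trifluoromethyl)cyclopropyl with its three-membered ring and three fluorines, gives no number lower than those of compound 1 and compound 2, so phenyl, tert-butyl and this group have produced no gain in strength at this place. The set now also touches the end of the measurable range: the limit of > 1000 nM in this assay, at which 1 of the 3 values shown sits.

As far as these compounds go, whether compound 3 truly differs from compound 2, or whether all three sit at a similar level, stays open. Also open, from the compounds shown here alone, is whether a much smaller group on the same carbon, such as a fluorine, a nitrile, an amine or a carboxylic acid, would give a reading clearly lower than these, and whether changes elsewhere on the shared core matter more than this position.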